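The compounds below may be only part of what the source reports. "The series", "measured", "known", "first", "only" and "open" are said of these compounds alone.

The measured compounds:
compound 1, `CC(C)=CC[C@@H](OC(=O)c1ccco1)C1=CC(=O)c2c(O)ccc(O)c2C1=O`, with > 100000 nM in a functional assay on DU-145 cells (Homo sapiens) for cytotoxicity, read by MTT assay; a lower number here means a stronger inhibitor, a higher number a weaker inhibitor;
compound 2, `CC(=O)OCCO[C@H](CC=C(C)C)C1=CC(=O)c2c(O)ccc(O)c2C1=O`, with 15500 nM in this assay.

Compound 1 gives only a limit in this assay, (the limit of > 100000 nM in this assay, at which 1 of the 2 values shown sits), so its actual number is not known. Compound 2 is thus the only one of the two with a measured number, and in this assay compound 2 gives 15500 nM. Among the compounds with values here, the single measured step, an at least 6.4-fold lower number from compound 1 to compound 2 (0.80 log units; beyond the scatter), is at least modest, its full size hidden by the limit.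

Compound 3, `CCC(CO[C@H](CC=C(C)C)C1=CC(=O)c2c(O)ccc(O)c2C1=O)OC`, differs from compound 2 by 1-methoxypropyl in place of acetoxymethyl on a saturated chain carbon bound to an oxygen on a saturated carbon. Within the data shown here, the measured step concerns the exchange of (furan-2-yl)carbonyl for 2-acetoxyethyl on the oxygen on the saturated carbon; the change to compound 3 instead alters the chain beyond that oxygen while keeping a saturated chain attached there, so no measured step bears directly on it. With nothing measured on this part of the molecule, compound 3 is expected to land within the scatter of compound 2, the expected step being a 1.3-fold lower number from compound 2 to compound 3 (0.11 log units; within the scatter). Compound 3 is therefore estimated at 12000 nM in this assay, with a range from 4000 nM to 40000 nM.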

Compound 3, half-maximal inhibitory concentration: 45700 nM
Beside the measured number, compound 3's estimate is 3.8-fold (0.58 log units) below it; the whole stated range lies below it.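

Up to this point, only the exchange of the whole group on the oxygen on a saturated carbon had been seen. Compound 3 shows that the number in this assay also responds to a change further out along that chain, with a 2.9-fold higher number from compound 2 to compound 3 (0.47 log units; beyond the scatter), so a saturated chain on this oxygen does not by itself fix the value, and 1-methoxypropyl in place of acetoxymethyl gives a weaker inhibitor. Even so, the 2-methoxybutyl group still gives a stronger inhibitor than the (furan-2-yl)carbonyl group, with an at least 2.1-fold lower number from compound 1 to compound 3 (0.34 log units; beyond the scatter), and the true size of that step stays hidden because compound 1 gives only a limit: the limit of > 100000 nM in this assay, at which 1 of the 3 values shown sits.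

The step from acetoxymethyl to 1-methoxypropyl replaces the acetoxy ester with a methoxy ether and alters the carbon count in one move, so the compounds shown cannot separate these two parts of the change. They also leave open how this assay would read for a chain on this oxygen ending in an amine or a carboxylic acid, or for a simple unbranched longer chain.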